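The compounds below may be only part of what the source reports. "The series", "measured", "known", "first", "only" and "open" are said of these compounds alone.

In an ADME assay for permeability, using PAMPA, at pH 7.4 (on this read-out higher numbers stand for higher permeability and lower numbers for lower permeability), compound 2 `CN(C[C@H]1Cc2c(cccc2N2CCN(C3CC3)CC2)CN1)[C@H]1CCCc2cccnc21` gives 265 nm/s, the highest of three measured numbers, ahead of compound 1 `c1cnc2c(c1)CCC[C@@H]2N(CC1CC1)C[C@H]1Cc2c(cccc2N2CCNCC2)CN1` at 87 nm/s and compound 3 `CC(C)N(C[C@H]1Cc2c(cccc2N2CCNCC2)CN1)[C@H]1CCCc2cccnc21` at 16 nm/s. Compound 4 `CN1CCN(c2cccc3c2C[C@H](CN(C)[C@H]2CCCc4cccnc42)NC3)CC1` differs from compound 2 by one change, 4-cyclopropylpiperazin-1-yl to 4-methylpiperazin-1-yl: methyl in place of cyclopropyl on an amine nitrogen in a ring. Going by the values given here, no measured step alters this group. Among the compounds with values here, the nearest evidence is the swap of isopropyl for cyclopropylmethyl on an amine nitrogen, a 5.4-fold lower number from compound 1 to compound 3 (0.74 log units; beyond the scatter), which shows only that one small group exchanged for another can move this number beyond the scatter. A small shift to a lower number is therefore expected, an estimated 1.9-fold lower number from compound 2 to compound 4 (0.28 log units; within the scatter). For compound 4 the expected value is 140 nm/s, with an estimated range from 55 nm/s to 320 nm/s.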

Compound 4, apparent permeability: 996 nm/s
Beside the measured number, compound 4's estimate is 7.1-fold (0.85 log units) below it, outside the stated range (above it).
By their numbers in this assay, from the lowest: compound 3; then compound 1; then compound 2; then compound 4.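

Methyl in place of cyclopropyl on an amine nitrogen in a ring gives a 3.8-fold higher number from compound 2 to compound 4 (0.58 log units; beyond the scatter) in this assay. Going by these compounds alone, this is the first measured step at this position, and it shows that the group on this ring nitrogen can move the number beyond the scatter, here upward with the smaller group. Nothing measured here accounts for the step. Still open, as far as these compounds go, is where an ethyl group or a longer chain on this nitrogen would fall, and whether the step would hold with isopropyl or cyclopropylmethyl on the other amine nitrogen.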